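Swapping difluoromethoxy for 1-hydroxy-1-methylethyl

The compounds below may be only part of what the source reports. "The series", "measured", "known", "first", "only" and "open" are said of these compounds alone.

Values measured in an ADME assay on microsomes from liver (Rattus norvegicus) for metabolic stability, with a stated time of 10 min; on this read-out higher numbers stand for a more stable compound and lower numbers for a less stable compound:
Compound 1 `FC(F)(F)c1ccccc1-c1ccc2[nH]c(C3=NOC4(CCCCC4)C3)nc2c1`: 75%
Compound 2 `FC(F)(F)Oc1ccccc1-c1ccc2[nH]c(C3=NOC4(CCCCC4)C3)nc2c1`: 74%
Compound 3 `FC(F)Oc1ccccc1-c1ccc2[nH]c(C3=NOC4(CCCCC4)C3)nc2c1`: 59%

Among these three, compound 3 stands lowest, at 59%. The two higher compounds cannot be told apart, since the read-out runs a number 1 percentage points lower from compound 1 to compound 2 (within the scatter). Compound 3 lies clearly under both of them, with the read-out running a number 16 percentage points lower from compound 1 to compound 3 (beyond the scatter) and a number 15 percentage points lower from compound 2 to compound 3 (beyond the scatter).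

The next compound is compound 4 `CC(C)(O)c1ccccc1-c1ccc2[nH]c(C3=NOC4(CCCCC4)C3)nc2c1`, and the change is 1-hydroxy-1-methylethyl in place of difluoromethoxy on an aromatic carbon. In words, 1-hydroxy-1-methylethyl takes the place of difluoromethoxy on an aromatic carbon, ortho to a large group, while the shared core stays the same.

All three measured steps concern this same place, but none of them introduces the new group, so they give only a rough guide to size. The two steps that reach compound 3 are modest, and nothing in the data points to a direction for the new group. No step beyond the scatter is therefore expected in this assay, though a modest move either way remains possible. The step expected is a number 3 percentage points higher from compound 3 to compound 4 (within the scatter). For compound 4 the estimated value is 62%, within an expected range from 40% to 82%.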

Compound 4, percent of the compound remaining: 10%
Beside the measured number, compound 4's estimate is 52 percentage points above it; measured number outside the range, below it.
By their numbers in this assay, from the lowest: compound 4; then compound 3; then compounds 2 and 1 (each within the scatter of the next).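

In this assay, within the data shown here, this position proves far more sensitive to the group it carries than the earlier compounds showed: where those steps were at most modest, 1-hydroxy-1-methylethyl gives a number 49 percentage points lower from compound 3 to compound 4 (beyond the scatter), and the drop is as large or larger against the two other groups, with a number 64 percentage points lower from compound 2 to compound 4 (beyond the scatter) and a number 65 percentage points lower from compound 1 to compound 4 (beyond the scatter). Compound 4 therefore lies clearly under all three earlier compounds, even though the change from compound 3 keeps the count at 4 heavy atoms and brings in 1 hydrogen-bond donor, so a group of the same heavy-atom count can still move this read-out a long way. Nothing available here accounts for the size of this drop.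

The compounds shown leave open whether the loss goes with the hydroxyl of the new group or with its carbon framework. An isopropyl group, a methoxy group or an amine on the same aromatic carbon would be the kind of comparison that could separate these two, and could show whether the low value in this assay is particular to 1-hydroxy-1-methylethyl.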